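This account rests on a few compounds, and the source may have more. Where it says the series, first, only, none or still open, it means among the compounds named here.

Compounds measured so far:

Compound 1 `CCn1c(-c2ccccc2)nc2c(NC3CCC3)ncnc21`: in a functional assay on CHO cells for antagonist activity at adenosine receptor A2b (Homo sapiens), read by 33P incorporation, with a stated time of 20 min (a higher number here means a weaker inhibitor, a lower number a stronger inhibitor), compound 1 gives 1440 nM.
Compound 2 `CCCn1c(-c2ccccc2)nc2c(NC3CCC3)ncnc21`: in this assay compound 2 gives 774 nM.

Among the compounds with values here, on these two numbers compound 2 cannot be separated from compound 1: the only measured step, a 1.9-fold lower number from compound 1 to compound 2 (0.27 log units; within the scatter), is a methyl in place of hydrogen on a saturated chain carbon, two bonds along the chain from an aromatic nitrogen, and it stays within the scatter. Compound 2 is therefore the starting point with the smaller of two numbers that are, for practical purposes, the same.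

Compound 3 `CCCn1c(-c2ccccc2)nc2c(NC3CCCCC3)ncnc21` differs from compound 2 at another place entirely: cyclohexyl in place of cyclobutyl on a nitrogen on an aromatic ring. Within the data shown here, no measured step touches this position, so the one step available, which concerns the chain on the aromatic nitrogen, gives no guidance on the size or direction of this change. With nothing to argue for a shift, the step from compound 2 to compound 3 is expected to stay within the scatter, a 1.2-fold higher number from compound 2 to compound 3 (0.07 log units; within the scatter). The estimate for compound 3 in this assay is therefore 900 nM, with a range from 250 nM to 3500 nM that is kept wide for want of any bearing step.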

Compound 3, inhibition constant: 5310 nM
Estimate against measurement, compound 3: 5.9-fold (0.77 log units) below; the whole stated range lies below it.
By their numbers in this assay, from the lowest: compounds 2 and 1 (each within the scatter of the next); then compound 3.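

Within the data shown here, the position on the nitrogen on an aromatic ring, which no earlier step touched, does respond in this assay: cyclohexyl in place of cyclobutyl gives a 6.9-fold higher number from compound 2 to compound 3 (0.84 log units; beyond the scatter) and so, unlike the only earlier step, which lay on the chain on the aromatic nitrogen, this change lies beyond the scatter. Among these compounds, in this one pair, the six-membered carbon ring goes with the weaker inhibitor and the four-membered carbon ring with the stronger, while the rest of the structure stays the same, so the group on this nitrogen matters more here than the one chain change seen so far. Nothing shown accounts for the step, and the reason for it remains unknown.

As far as these compounds go, it remains open whether cyclopentyl on this nitrogen would stand with cyclobutyl or with cyclohexyl, and whether an open chain such as isobutyl, or a hydroxyl group on the cyclohexyl, would give a number as low as that of compound 2. Also open, from the compounds shown here alone, is whether the same exchange of rings would produce a step of similar size on the shorter chain of compound 1.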